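The source may hold more compounds than are shown below. What is called first, only, known or untested is meant among the compounds shown, and "the series" means these compounds.

Of the compounds shown here, three from one series have been tested in a functional assay on HT-29 cells (Homo sapiens) for cytotoxicity, read by MTT assay, with a stated time of 72 h; a lower number here means a stronger inhibitor, a higher number a weaker inhibitor. Compound 1 `COc1cc2c(Oc3ccc(NC(=O)c4cn(-c5ccccc5Cl)nn4)cc3F)ccnc2cc1OCCCN1CCCC1` gives 150 nM. Compound 2 `COc1cc2c(Oc3ccc(NC(=O)c4cn(-c5ccc(Br)cc5)nn4)cc3F)ccnc2cc1OCCCN1CCCC1` gives 190 nM. Compound 3 `COc1cc2c(Oc3ccc(NC(=O)c4cn(-c5ccccc5Cl)nn4)cc3F)ccnc2cc1OCCCN1CCC(C)CC1` gives 130 nM. The three numbers sit close together: compound 3 returns the lowest of them, but its gap to compound 1 and its gap to compound 2 both lie within the scatter, so no ranking among the three is claimed.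

The next compound, compound 4 `COc1cc2c(Oc3ccc(NC(=O)c4cn(-c5ccc(F)c(F)c5)nn4)cc3F)ccnc2cc1OCCCN1CCC(C)CC1`, differs from compound 3 in one place: 3,4-difluorophenyl in place of 2-chlorophenyl on an aromatic nitrogen. Two measured steps frame this change. The step of a 1.2-fold lower number from compound 1 to compound 3 (0.06 log units; within the scatter) shows that the amine exchange leading to compound 3 left the number essentially where it was. More directly relevant is the step of a 1.3-fold higher number from compound 1 to compound 2 (0.10 log units; within the scatter), in which a different aryl group on the same aromatic nitrogen also produced no shift beyond the scatter. Going by the values given here, with only that one precedent for an aryl exchange at this position, and with it showing no movement, the expected step of a 1.2-fold higher number from compound 3 to compound 4 (0.06 log units; within the scatter) is none beyond the scatter. Compound 4 is therefore estimated at 150 nM, with a range from 60 nM to 400 nM.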

Compound 4, half-maximal inhibitory concentration: 810 nM
Estimate against measurement, compound 4: 5.4-fold (0.73 log units) below; measured number above the stated range.
By their numbers in this assay, from the lowest: compounds 3, 1 and 2 (each within the scatter of the next); then compound 4.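

In this assay, going by these compounds alone, the aryl group on the aromatic nitrogen of the five-membered ring turns out not to be freely exchangeable: 3,4-difluorophenyl in place of 2-chlorophenyl gives a 6.2-fold higher number from compound 3 to compound 4 (0.79 log units; beyond the scatter), the first step beyond the scatter. Set against the earlier aryl exchange at the same nitrogen, a 1.3-fold higher number from compound 1 to compound 2 (0.10 log units; within the scatter), this shows that the number at this position can respond strongly, and that the response depends on the aryl pair exchanged, on the amine at the end of the chain, or on both. Within the data shown here, no measurement offered here explains why this exchange moves the number so far.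

The two aryl steps differ in both the groups exchanged and the amine carried, pyrrolidin-1-yl in one and 4-methylpiperidin-1-yl in the other, so the compounds shown leave open whether 3,4-difluorophenyl would give a similar step alongside pyrrolidin-1-yl. They also leave open whether the step follows from the departure of 2-chlorophenyl or the arrival of 3,4-difluorophenyl, a question that plain phenyl, 3-fluorophenyl or 4-fluorophenyl at the same nitrogen would help to separate.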